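The source may hold more compounds than are shown below. What is called first, only, known or untested is meant among the compounds shown, and "the series" means these compounds.

The series opens with compound 1, `O=[N+]([O-])c1ccc2c(c1)CN(c1ncnc3c1nc1n3[C@@H]3O[C@H](CO1)[C@@H](O)[C@H]3O)CC2`, which in an assay on isolated protein for binding affinity to Equilibrative nucleoside transporter 1 (Homo sapiens) (a higher number here means a weaker inhibitor, a lower number a stronger inhibitor), gives 331 nM, and compound 2, `CCC(C)Sc1nc(N)nc2c1ncn2[C@@H]1O[C@H](CO)[C@@H](O)[C@H]1O`, which in this assay gives 63100 nM. Of these two numbers compound 2 stands highest, and its nearest neighbour is compound 1, which shows a far lower value; the two differ at more than one place, so their gap speaks only of the two values as they stand. The account now follows the step from compound 2 to compound 3, `CC(=O)c1cc(Cl)ccc1Sc1nc(N)nc2c1ncn2[C@@H]1O[C@H](CO)[C@@H](O)[C@H]1O`. The change is 2-acetyl-4-chlorophenyl in place of sec-butyl on a sulfur. Among the measured compounds shown here, no pair differing in a single place has been measured, so the size of the step is uncertain; compound 3 is expected to show a lowered number, as a 13-fold lower number from compound 2 to compound 3 (1.10 log units; beyond the scatter), because compound 1, which carries a larger aromatic group on the same core, gives 331 nM. Compound 3 is therefore estimated at 5000 nM, within a range from 800 nM to 30000 nM.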

Compound 3, half-maximal inhibitory concentration: 14500 nM
Beside the measured number, compound 3's estimate is 2.9-fold (0.46 log units) below it, and the stated range covers the measured number.
By their numbers in this assay, from the lowest: compound 1; then compound 3; then compound 2.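

Among the compounds shown here, replacing sec-butyl with 2-acetyl-4-chlorophenyl on a sulfur whose other neighbour is an aromatic carbon gives, in this assay, a 4.4-fold lower number from compound 2 to compound 3 (0.64 log units; beyond the scatter) and this is the first comparison that differs in one place. The step is modest but lies beyond the usual scatter, so this position accepts an aromatic ring carrying an acetyl and a chlorine in place of a branched chain, and the number falls. No measurement here shows which part of the entering group accounts for the step.

The compounds shown leave open whether a plain phenyl, or a phenyl carrying only the acetyl or only the chlorine, would give the same step. They also leave open how a benzyl group or a longer alkyl chain on this sulfur would compare.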